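Working notes on the aromatic substituent of compound 1

The source may report more compounds than this note shows. Statements on the series, on what has been measured and on what is new or still open speak of the compounds shown alone.

Compound 1 `Cc1ccc2c(c1)[n+]([O-])c(NCCN(C)C)n[n+]2[O-]` is the reference point in a physicochemical assay for solubility, in the presence of a further agent that is not named here; a lower number here means a less soluble compound, a higher number a more soluble compound. In this assay compound 1 gives > 51000000 nM, which is a limit of the assay and not a number (the limit of > 51000000 nM in this assay, at which 1 of the 3 values shown sits). Compound 2 `CCN(CC)CCNc1n[n+]([O-])c2ccc(C)cc2[n+]1[O-]` in this assay gives > 49000000 nM, also a limit (the limit of > 49000000 nM in this assay, at which 1 of the 3 values shown sits). Compound 3 `Cc1ccc2c(c1)[n+]([O-])c(NCCN1C(C)CCCC1C)n[n+]2[O-]` in this assay gives 48000000 nM. All measured steps vary the amine at the end of the chain: a step that the two limits leave unreadable from compound 1 to compound 2, an at least 1.0-fold lower number from compound 1 to compound 3 (0.02 log units; that floor lies within the scatter) and an at least 1.0-fold lower number from compound 2 to compound 3 (0.00 log units; that floor lies within the scatter). Compound 4 `CN(C)CCNc1n[n+]([O-])c2ccc(C(C)(C)C)cc2[n+]1[O-]` instead changes the aromatic ring of the shared core: tert-butyl in place of methyl on an aromatic carbon. Among the measured compounds shown here, no measured step touches this position, so none bears directly on it; the series so far shows every compound sitting at or close to the same level. Compound 4 is therefore expected to remain in that region, the expected step being an at least 2.0-fold lower number from compound 1 to compound 4 (0.30 log units; that floor lies within the scatter). Compound 4 is estimated at 25000000 nM in this assay, with a range from 5000000 nM to 51000000 nM.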

Compound 4, solubility: 38000000 nM
Beside the measured number, compound 4's estimate is 1.5-fold (0.18 log units) below it; measured number inside the range.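

The aromatic carbon that carries methyl in the shared core now has its first reading: in this assay, tert-butyl in place of methyl, with 4 heavy atoms entering for 1, gives an at least 1.3-fold lower number from compound 1 to compound 4 (0.12 log units; that floor lies within the scatter). Change so far had been seen only at the amine at the end of the chain, and this exchange on the aromatic ring also shows no step beyond the scatter. That step is only a floor, because compound 1 stands at a limit of the assay: the limit of > 51000000 nM in this assay, at which 1 of the 4 values shown sits.

On these data alone, what a carboxylic acid or an aminomethyl group in place of methyl would give on this aromatic carbon stays open. Also open, as far as these compounds go, is whether tert-butyl gives the same picture with diethylamino or 2,6-dimethylpiperidin-1-yl at the end of the chain.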